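This account rests on a few compounds, and the source may have more. Where it says the series, first, only, none or still open, it means among the compounds named here.

In a physicochemical assay for solubility, using the shake flask method, in phosphate buffer, with a stated time of 90 min, at pH 6.8 (a lower number here means a less soluble compound, a higher number a more soluble compound), compound 1 (`COc1cc(/C=C/C(=O)/C=C(/C=C/c2ccc(O)c(OC)c2)NCCCO)ccc1O`) gives 25400 nM and compound 2 (`COCCNC(=C\C(=O)/C=C/c1ccc(O)c(OC)c1)/C=C/c1ccc(O)c(OC)c1`) gives 16700 nM, so these two stand within the scatter of each other. Compound 3 (`COCCCNC(=C\C(=O)/C=C/c1ccc(O)c(OC)c1)/C=C/c1ccc(O)c(OC)c1`) differs from compound 2 by methoxymethyl in place of methoxy on a saturated chain carbon, two bonds along the chain from an amine nitrogen. One measured step touched that same place, a 1.5-fold lower number from compound 1 to compound 2 (0.18 log units; within the scatter), and it stayed within the scatter. No shift beyond the scatter is therefore expected, and the estimated step is a 1.1-fold lower number from compound 2 to compound 3 (0.05 log units; within the scatter). For compound 3 the expected value is 15000 nM, with an estimated range of 7000 nM to 30000 nM.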

Compound 3, solubility: 7700 nM
Compound 3: the middle estimate sits 1.9-fold (0.29 log units) above what was measured; low and high end bracket the measured number.
By their numbers in this assay, from the lowest: compound 3; then compounds 2 and 1 (each within the scatter of the next).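

In this assay, among these compounds, this position responds to a small edit for the first time: the change from (2-methoxyethyl)amino to (3-methoxypropyl)amino gives a 2.2-fold lower number from compound 2 to compound 3 (0.34 log units; beyond the scatter) and so ends the earlier impression of a position where such edits change little. Methyl in place of hydrogen on an oxygen on a saturated carbon gives a 3.3-fold lower number from compound 1 to compound 3 (0.52 log units; beyond the scatter) as a second step of modest size. Going by these compounds, whether a longer chain, or an amine or a carboxylic acid in place of the methoxy, would move the number further stays open. Nothing measured here explains either step.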